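Dropping the amide from a benzyl-bearing aryloxypropanolamine

The source may report more compounds than this note shows. Statements on the series, on what has been measured and on what is new or still open speak of the compounds shown alone.

Measured so far:
compound 1 `CCCCOc1ccc(OCCCNC(C)C)cc1` — 56 nM
compound 2 `CCC(=O)Nc1ccc(OCC(O)CNC(C)C)c(Cc2ccccc2)c1` — 900 nM

Two compounds have numbers in an assay for inhibition of squalene synthase (Rattus norvegicus), using microsomes; on this read-out higher numbers stand for weaker inhibition and lower numbers for stronger inhibition. Compound 1 `CCCCOc1ccc(OCCCNC(C)C)cc1` gives 56 nM in this assay, and compound 2 `CCC(=O)Nc1ccc(OCC(O)CNC(C)C)c(Cc2ccccc2)c1` gives 900 nM. Compound 2 therefore has the higher of the two numbers, and the gap to compound 1 is wide enough to lie beyond the usual scatter. For the measured compounds named here, the two compounds differ in several places at once, so the values alone show only that compound 1 is the stronger inhibitor of the pair.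

Compound 3 `CC(C)NCC(O)COc1ccccc1Cc1ccccc1` has not yet been measured. It differs from compound 2 in a single place: hydrogen in place of propanoylamino on an aromatic carbon. Going by the values given here, no measured pair shows this change on its own, so its effect is not known from the data. Compound 3 is expected to give a number somewhat lower than that of compound 2, as a modest step, since compound 2 carries the highest number shown and compound 1, with no such group, gives 56 nM. The expected step is a 2.3-fold lower number from compound 2 to compound 3 (0.35 log units; beyond the scatter). For compound 3 the estimate is 400 nM, in a range from 120 nM to 1500 nM.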

Compound 3, half-maximal inhibitory concentration: 8800 nM
Beside the measured number, compound 3's estimate is 22-fold (1.34 log units) below it, and the stated range ends below it.
By their numbers in this assay, from the lowest: compound 1; then compound 2; then compound 3.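

In this assay, replacing the propanoylamino group with hydrogen gives a 9.8-fold higher number from compound 2 to compound 3 (0.99 log units; beyond the scatter) and so weakens inhibition by a margin beyond the usual scatter. For the compounds shown here, this is the first pair that differs in only one place, so the change can be read on its own, which the earlier comparison between compound 1 and compound 2 did not allow. It shows that this aromatic carbon, meta to the benzyl group and para to the 2-hydroxy-3-(isopropylamino)propoxy group, is not indifferent to what it carries, and that within this pair the compound bearing propanoylamino is the stronger inhibitor.

This single pair leaves open whether other groups at this carbon, such as a plain amine, an acetylamino group, a longer acylamino chain or a carboxylic acid, would keep, lose or improve inhibition, and whether the same exchange would have a similar effect on a different core. No supporting measurement shown here explains the step, so the part of the propanoylamino group that matters, whether its carbonyl, its amide hydrogen or its chain, remains unknown.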